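Benzyl for Cyclohexyl: a Second Look at One Swap

A few compounds are considered here, and "the series" means these few. Any claim that something is new, unique, unknown or untested is made for them only; others in the source may bear on it.

Compound 1 `O=Cc1ccc(-c2cn3ccnc3c(-c3ccc4ncn(C5CCCCC5)c4c3)n2)cc1` and compound 2 `O=Cc1ccc(-c2cn3ccnc3c(-c3ccc4ncn(Cc5ccccc5)c4c3)n2)cc1` share one core and differ in one place: benzyl in place of cyclohexyl on an aromatic nitrogen. In a functional assay on A498 cells (Homo sapiens) for inhibition, read by sulforhodamine B assay, with a stated time of 48 h, tested at 10 uM (a higher number here means more inhibition at the concentration tested (going by the name of the read-out), a lower number less inhibition), compound 1 gives 11.2% and compound 2 gives 11.2%, so the step of no change at the digits printed from compound 1 to compound 2 (within the scatter). Compound 3 `c1cn2cc(-c3ccc4c(c3)ncn4C3CCCCC3)nc(-c3ccc4ncn(C5CCCCC5)c4c3)c2n1` is built on a different core; the difference between the two cores is not broken down here. In this assay compound 3 gives 16.3%. Compound 4 `c1ccc(Cn2cnc3ccc(-c4nc(-c5ccc6c(c5)ncn6C5CCCCC5)cn5ccnc45)cc32)cc1` has not yet been measured and differs from compound 3 by the same change, (benzyl in place of cyclohexyl on an aromatic nitrogen). Because the earlier step of no change at the digits printed from compound 1 to compound 2 (within the scatter) stayed within the scatter, compound 4 is expected to show a step of a number 1.3 percentage points lower from compound 3 to compound 4 (within the scatter). Compound 4 is estimated at 15%, with a likely range from 4% to 26%.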

Compound 4, a percentage reported as inhibition, at one concentration (the size of the read-out at that concentration, not a potency): -71.8%
The estimate for compound 4 lay 86.8 percentage points above the measured number; the whole stated range lies above it.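

On the core of compound 3, benzyl in place of cyclohexyl on an aromatic nitrogen gives a number 88.1 percentage points lower from compound 3 to compound 4 (beyond the scatter) in this assay. The same swap therefore does not behave alike on these two cores, and a flat step on one core proved no guide to the step on the other: the same change on two cores in this assay, no change at the digits printed (within the scatter) from compound 1 to compound 2 and a number 88.1 percentage points lower (beyond the scatter) from compound 3 to compound 4, 88.1 percentage points apart, beyond the scatter of two such steps

This does not show why the two cores part ways, and a single pair on each core says nothing about how any other swap would carry over.

The compounds shown carry only cyclohexyl or benzyl at this nitrogen. From the compounds shown here alone, how a longer chain ending in an amine or a carboxylic acid would read there in this assay, on either core, remains open.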